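Hydroxylated enyne tail: efficacy outlook for compound 3

The source may hold more compounds than are shown below. What is called first, only, known or untested is meant among the compounds shown, and "the series" means these compounds.

Compound 1 `C/C=C(\C)C#Cc1ccc(CCC(=O)O)c(F)c1` and compound 2 `C/C=C/C#Cc1ccc(CCC(=O)O)c(F)c1` share one core and differ only in the group on a triple-bonded carbon. In a functional assay on 1321-N1 cells for agonist activity at Free fatty acid receptor 1 (Homo sapiens), read by calcium flux, with a stated time of 0.4 s (on this read-out higher numbers stand for larger maximal responses and lower numbers for smaller maximal responses), compound 1 gives 97% and compound 2 gives 97%. The step of no change at the digits printed from compound 1 to compound 2 (within the scatter) is therefore flat. Compound 2 stands level with compound 1 at the digits shown; no other measured compound exists to place it against.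

Compound 3 `C/C(C#Cc1ccc(CCC(=O)O)c(F)c1)=C/CO` differs from compound 2 by 3-hydroxy-1-methylprop-1-en-1-yl in place of prop-1-en-1-yl on a triple-bonded carbon. Within the data shown here, the only measured step that touches this position is no change at the digits printed from compound 1 to compound 2 (within the scatter), which was within the scatter, so one alteration of the enyne group left the maximal response where it was. Among the measured compounds shown here, no measured step involves a group resembling the entering one; the data hold no comparison for it, and the expectation rests on the single flat step alone.

Compound 3 is expected at 92% in this assay, within a range from 70% to 105%, because no change at the digits printed from compound 1 to compound 2 (within the scatter) gave no change at this position. The expected step of a number 5 percentage points lower from compound 2 to compound 3 (within the scatter) is thus estimated to lie within the scatter, with the range widened for the unprecedented group.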

Compound 3, largest response reached (reported as efficacy), in percent of the reference or control that the assay uses: 105%
For compound 3 the middle estimate is 13 percentage points below the measured one, within the range that was stated.
By their numbers in this assay, from the lowest: compounds 1, 2 and 3 (each within the scatter of the next).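

In this assay, the 3-hydroxy-1-methylprop-1-en-1-yl group on a triple-bonded carbon gives a number 8 percentage points higher from compound 2 to compound 3 (within the scatter) when set against prop-1-en-1-yl, and a number 8 percentage points higher from compound 1 to compound 3 (within the scatter) when set against 1-methylprop-1-en-1-yl. Among these compounds, the earlier pair showed only that one all-carbon group could replace another at this place without a change beyond the scatter; these steps extend that reading to a group with oxygen, a hydrogen-bond donor and a hydrogen-bond acceptor, so the maximal response stays within the scatter across all three groups. Nothing available accounts for this outcome or ties it to any property of the entering group.

Open, from the compounds shown here alone, is whether the flat picture holds for groups of another kind on the same triple-bonded carbon, such as an amine, a carboxylic acid or a longer chain ending in a hydroxy group, any of which could show whether a step beyond the scatter exists here at all. Also open is whether the hydroxy group itself matters, since compound 3 carries it together with the methyl branch and no compound shown separates the two within a single change.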